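The source may hold more compounds than are shown below. What is called first, only, known or untested is meant among the compounds shown, and "the series" means these compounds.

Compound 1 `COC(=O)C1=C(N)Oc2c(OC)cc(Br)cc2C1CC(=O)c1ccc(Cl)cc1`, compound 2 `COC(=O)C1=C(N)Oc2c(OC)cc(Br)cc2C1CC(=O)c1ccc(Br)cc1` and compound 3 `COC(=O)C1=C(N)Oc2ccc(Br)cc2C1CC(=O)c1ccccc1` were studied in a functional assay on MCF7 cells (Homo sapiens) for antiproliferative activity, read by sulforhodamine B assay, with a stated time of 72 h, tested at 10 uM; on this read-out higher numbers stand for a weaker effect at the one concentration tested and lower numbers for a stronger effect. Compound 1 gives 80.3%, compound 2 gives 50.2%, and compound 3 gives 107%, the highest of the three numbers. The change from compound 2 to compound 1 is chloro in place of bromo on an aromatic carbon, and its step is a number 30.1 percentage points higher from compound 2 to compound 1 (beyond the scatter). How the core of compound 3 differs from that of compound 2 is not broken down here.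

Compound 4 `COC(=O)C1=C(N)Oc2ccc(Cl)cc2C1CC(=O)c1ccccc1` has not yet been measured in this assay. Its difference from compound 3 is chloro in place of bromo on an aromatic carbon. This is the same kind of change as that from compound 2 to compound 1, not the same: there the chlorine sits on a six-membered aromatic ring of carbon only, para to a large group, whereas here it sits on a ring that is part of a fused system, meta and para to a fused ring. The earlier step raised the number. For compound 4 a much smaller step is expected, a number 2 percentage points lower from compound 3 to compound 4 (within the scatter), because compound 3 already stands at 107%, close to no effect, and the place of the change is different. Compound 4 is therefore estimated at 105%, expected between 88% and 122%.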

Compound 4, a percentage reported as activity, at one concentration (the size of the read-out at that concentration, not a potency): 87.2%
Compound 4: middle estimate off by 17.8 percentage points, on the high side; measured number outside the range, below it.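

In this assay, chloro in place of bromo on an aromatic carbon gives a number 19.8 percentage points lower from compound 3 to compound 4 (beyond the scatter), while the same exchange on the other core gave a number 30.1 percentage points higher from compound 2 to compound 1 (beyond the scatter), so the change carries over from one core to the other with neither its size nor its direction intact: the same change on two cores in this assay, a number 30.1 percentage points higher (beyond the scatter) from compound 2 to compound 1 and a number 19.8 percentage points lower (beyond the scatter) from compound 3 to compound 4, 49.9 percentage points apart, beyond the scatter of two such steps Chloro therefore goes with a stronger effect in compound 4 than in compound 3, but with a weaker effect in compound 1 than in compound 2, and neither halogen is favoured across the compounds shown. The two pairs differ both in their core and in the ring that carries the halogen, so these data cannot say which of the two differences goes with the reversal, and two pairs give no rule for any further core.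

The compounds shown leave open how fluoro, iodo or methyl would read at either of these places. They also leave open whether either step would hold with a carboxylic acid in place of the methyl ester, or at concentrations other than the one tested.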